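From 3,5-dimethylphenyl to 3,4-dimethylphenyl on the sulfonyl

This account rests on a few compounds, and the source may have more. Where it says the series, first, only, none or still open, it means among the compounds named here.

Three compounds have been measured in an assay on isolated protein for displacement of a labelled ligand from metabotropic glutamate receptor 5 (Homo sapiens), with a stated time of 60 min, tested at 1 uM; on this read-out higher numbers stand for more inhibition at the one concentration tested (going by the name of the read-out) and lower numbers for less inhibition:
compound 1 `CC1CCN(c2c(S(=O)(=O)c3cc(F)cc(F)c3)cnc3cc(F)ccc23)CC1` gives 77%;
compound 2 `Cc1ccc(S(=O)(=O)c2cnc3cc(Cl)ccc3c2N2CCC(C)CC2)cc1C` gives 86%;
compound 3 `Cc1cc(C)cc(S(=O)(=O)c2cnc3cc(F)ccc3c2N2CCC(C)CC2)c1` gives 80%.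

Compound 3 sits between the other two numbers, and both compound 1 and compound 2 lie within the scatter of it, so no order among the three can be read. Within the data shown here, the one step that touches the phenyl on the sulfonyl sulfur, a number 3 percentage points higher from compound 1 to compound 3 (within the scatter), stayed within the scatter. Compound 4 `Cc1ccc(S(=O)(=O)c2cnc3cc(F)ccc3c2N2CCC(C)CC2)cc1C` differs from compound 3 by 3,4-dimethylphenyl in place of 3,5-dimethylphenyl on a sulfonyl sulfur. Among the measured compounds shown here, no measured step changes the pattern of two methyl groups on that ring, so the expected step of no change at the digits printed from compound 3 to compound 4 (within the scatter) is none beyond the scatter. Compound 4 is therefore estimated at 80%, between 68% and 90%.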

Compound 4, a percentage reported as inhibition, at one concentration (the size of the read-out at that concentration, not a potency): 90%
Estimate against measurement, compound 4: 10 percentage points below, and the stated range covers the measured number.
By their numbers in this assay, from the lowest: compounds 1, 3, 2 and 4 (each within the scatter of the next, the first and the last beyond it).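

In this assay, moving one methyl group to give 3,4-dimethylphenyl on the sulfonyl sulfur produces a number 10 percentage points higher from compound 3 to compound 4 (within the scatter) and so cannot be read as a gain. Fluoro in place of chloro on an aromatic carbon gives a number 4 percentage points higher from compound 2 to compound 4 (within the scatter) and separates neither compound. Only the exchange of 3,5-difluorophenyl for 3,4-dimethylphenyl, a number 13 percentage points higher from compound 1 to compound 4 (beyond the scatter), clears the scatter, and only modestly. Nothing measured here accounts for these numbers. Going by these compounds, whether a carboxylic acid, an amine or a longer chain on that phenyl would hold the number stays open.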